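Amino for ethoxy on the chain of compound 2

A few compounds are considered here, and "the series" means these few. Any claim that something is new, unique, unknown or untested is made for them only; others in the source may bear on it.

Measured in an ADME assay on L929 cells (Mus musculus) for cytotoxicity, read by resazurin assay, with a stated time of 48 h; a higher number here means that more compound is tolerated, a lower number that less compound is tolerated:
- compound 1 `C=Cn1c2ccc([N+](=O)[O-])cc2c(=O)n1Cc1ccccc1`: 160000 nM
- compound 2 `CCOC(=O)CCCn1c2ccc([N+](=O)[O-])cc2c(=O)n1Cc1ccccc1`: 78100 nM

Of these two, compound 2 holds the lower number in this assay, at 78100 nM. Compound 3 `NC(=O)CCCn1c2ccc([N+](=O)[O-])cc2c(=O)n1Cc1ccccc1` has not been measured. It carries amino in place of ethoxy on a carbonyl carbon, so ethoxycarbonyl becomes carbamoyl (amino in place of ethoxy on a carbonyl carbon).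

For the measured compounds named here, only one measured step bears on this change, and only indirectly: a 2.0-fold lower number from compound 1 to compound 2 (0.31 log units; beyond the scatter). That step introduced the chain now being altered and was modest. Going by the values given here, no measured compound carries carbamoyl, so the direction rests on little. A small move towards a higher number is the working assumption, with nothing expected beyond the scatter. The expected change is a 1.4-fold higher number from compound 2 to compound 3 (0.15 log units; within the scatter). Compound 3 is estimated at 110000 nM, with an expected range of 45000 nM to 250000 nM.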

Compound 3, concentration lethal to 50% of the cells: > 256000 nM
Compound 3: only a limit was reported; the forecaster's own chance of this, stated with the estimate: 10%; middle value at least 2.3-fold (0.36 log units) away from the limit.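

In this assay, the end of the chain proves to matter: amino in place of ethoxy on a carbonyl carbon gives an at least 3.2-fold higher number from compound 2 to compound 3 (0.51 log units; beyond the scatter), a change at a site that the earlier pair of compounds left untested. Compound 3 yields a limit and not a number, so the full size of this step stays undefined: the limit of > 256000 nM in this assay, at which 1 of the 3 values shown sits. Set against the vinyl group, 3-carbamoylpropyl gives an at least 1.6-fold higher number from compound 1 to compound 3 (0.20 log units; that floor lies within the scatter), so the chain does not by itself bring the lower number seen with compound 2, although this comparison gives no firm separation of the two compounds.

Open, as far as these compounds go, is whether a carboxylic acid or a methylamide at the end of the same chain would behave like ethoxycarbonyl or like carbamoyl. Also open, from the compounds shown here alone, is whether a longer chain ending in carbamoyl would keep the number of compound 3 at the limit.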